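Swapping a Methylphenyl for a Chlorophenyl on the Phenoxy Arm

This account rests on a few compounds, and the source may have more. Where it says the series, first, only, none or still open, it means among the compounds named here.

Compound 1, `N[C@@H](COP(=O)(O)OCCCOC(=O)CCc1ccccc1OCCCCOc1ccccc1)C(=O)O`: 6.1%
Compound 2, `Cc1ccccc1Oc1cccc(COc2ccccc2CCC(=O)OCCCOP(=O)(O)OC[C@H](N)C(=O)O)c1`: 20.3%

Two compounds share a serine-phosphate core linked through an ester to an aryl ether, and both have been tested in an assay on cells for agonist activity at probable G-protein coupled receptor 34 (Mus musculus), with a stated time of 1 h; on this read-out lower numbers stand for smaller maximal responses and higher numbers for larger maximal responses. Compound 2 gives 20.3% in this assay, the higher of the two numbers; compound 1 gives 6.1%, which is lower by a margin beyond the usual scatter. Compound 2 is thus the stronger of the two on this read-out, though both maximal responses are modest.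

Compound 3, `N[C@@H](COP(=O)(O)OCCCOC(=O)CCc1ccccc1OCc1cccc(Oc2ccc(Cl)cc2)c1)C(=O)O`, differs from compound 2 in one place: 4-chlorophenyl in place of 2-methylphenyl on an oxygen on an aromatic ring. Among the compounds with values here, no measured pair shows this exchange, so the size of its effect is unknown. With a single aromatic ring replaced by another of the same size and the same count of donors and acceptors, the expected step is small, quite possibly none beyond the scatter, and its direction is open; the estimate here is a number 2.3 percentage points lower from compound 2 to compound 3 (within the scatter). For compound 3 the expected maximal response in this assay is 18%, with a likely range from 5% to 40%.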

Compound 3, largest response reached (Emax), in percent of the reference or control that the assay uses: 17.8%
Compound 3: middle estimate off by 0.2 percentage points, on the high side, and the stated range covers the measured number.
By their numbers in this assay, from the lowest: compound 1; then compounds 3 and 2 (each within the scatter of the next).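

In this assay, the exchange of 2-methylphenyl for 4-chlorophenyl on an oxygen on an aromatic ring comes out as a number 2.5 percentage points lower from compound 2 to compound 3 (within the scatter), so the two compounds cannot be told apart on this read-out. Within the data shown here, this is the first pair that differs in one place, and it shows that this position can carry either of these two rings with no difference beyond the scatter, although the pair alters both the substituent and its place on the ring and cannot separate the two. Nothing available gives a reason for this result or bears on how the two rings compare.

Still open, as far as these compounds go, is whether unsubstituted phenyl, 2-chlorophenyl or 4-methylphenyl on the same oxygen would read alike, which would separate the identity of the substituent from its place, and whether a carboxylic acid or an amine on this ring would give a larger maximal response. Also open, from the compounds shown here alone, is whether the same exchange would read alike with a longer chain carrying the phosphate.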